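Swapping one aryl group on a cytotoxic chalcone-like compound

The compounds below may be only part of what the source reports. "The series", "measured", "known", "first", "only" and "open" are said of these compounds alone.

Compound 1 (`COc1cc(/C=C/C(=O)c2ccc(N)c(-c3ccc(F)cc3)c2)cc(Br)c1O`): 22900 nM
Compound 2 (`COc1ccc(/C=C/C(=O)c2ccc(N)c(-c3ccc(F)cc3)c2)cc1`): 7230 nM
Compound 3 (`O=C(/C=C/c1ccc(Br)cc1)c1cccc(-c2cccc(F)c2)c1`): 18200 nM

All three numbers come from a functional assay on SW480 cells (Homo sapiens) for cytotoxicity, read by sulforhodamine B assay, with a stated time of 48 h; a lower number here means a stronger inhibitor, a higher number a weaker inhibitor. Compound 3 (18200 nM) lies within the usual scatter of compound 1 (22900 nM), so that pair cannot be told apart. Compound 2 (7230 nM) gives a lower number than compound 3, and that gap is beyond the scatter, which makes compound 3 the weaker of those two.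

Within the data shown here, the next compound, compound 4 (`COc1ccccc1/C=C/C(=O)c1cccc(-c2cccc(F)c2)c1`), has no measurement yet. It carries 2-methoxyphenyl in place of 4-bromophenyl on a double-bonded chain carbon bound to a double-bonded chain carbon, and the rest of the molecule stays the same.

Among the measured compounds shown here, no two measured compounds differ in only one place, so the data offer no direct guide to this swap. Compound 3 (18200 nM) is the closest measured relative and therefore serves as the starting point. With nothing to suggest a direction, the expected change in this assay is a 1.2-fold lower number from compound 3 to compound 4 (0.08 log units; within the scatter) and thus nothing beyond the scatter. Compound 4 is estimated at 15000 nM (range 6000 nM to 38000 nM).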

Compound 4, half-maximal inhibitory concentration: 16600 nM
Compound 4: the middle estimate sits 1.1-fold (0.04 log units) below what was measured, and the stated range covers the measured number.
By their numbers in this assay, from the lowest: compound 2; then compounds 4, 3 and 1 (each within the scatter of the next).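

In this assay, among these compounds, the swap of 4-bromophenyl for 2-methoxyphenyl on a double-bonded chain carbon bound to a double-bonded chain carbon gives a 1.1-fold lower number from compound 3 to compound 4 (0.04 log units; within the scatter) and is the first change here that can be read in isolation, since the earlier compounds all differ in more than one place. At this position, the two aryl groups cannot be told apart, even though one carries bromine and the other brings an oxygen, one more heavy atom and a hydrogen-bond acceptor. No measured evidence accompanies this result to explain why the number barely moves.

Compound 2 gives the lowest number at 7230 nM, but it differs from compound 3 and compound 4 in more than one place, so the compounds shown do not reveal which of its features goes with that number. On these data alone, it also remains open whether this position would stay as insensitive to a phenyl ring carrying an amine or a carboxylic acid, or to a longer chain in place of the ring.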